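The source may hold more compounds than are shown below. What is called first, only, known or untested is meant among the compounds shown, and "the series" means these compounds.

Series notes. Compound 1 `O=C(Nc1cccc(-n2cc(-c3ccncc3)c(-c3cc(O)cc(Cl)c3)n2)c1)Nc1ccc(Cl)c(C(F)(F)F)c1` gives 106% in a functional assay on HCC 2998 cells (Homo sapiens) for inhibition, read by sulforhodamine B assay, with a stated time of 48 h, tested at 1 uM; on this read-out lower numbers stand for a stronger effect and higher numbers for a weaker effect at the one concentration tested; compound 2 `O=C(Nc1cccc(-n2cc(-c3ccncc3)c(-c3cc(O)cc(Cl)c3)n2)c1)Nc1ccc(Cl)c(Cl)c1` gives 96% in this assay; compound 3 `COc1cc(Cl)cc(-c2nn(-c3cccc(NC(=O)Nc4ccc(Cl)c(Cl)c4)c3)cc2-c2ccncc2)c1` gives 91% in this assay. Compound 3 stands at the lowest of the three numbers, with compound 2 nearest and compound 1 furthest; the step of a number 10 percentage points lower from compound 1 to compound 2 (within the scatter) and the step of a number 5 percentage points lower from compound 2 to compound 3 (within the scatter) are both within the scatter, so the three compounds read alike. Compound 4 `COc1cc(Cl)cc(-c2nn(-c3cccc(NC(=O)c4cccc(C(F)(F)F)c4)c3)cc2-c2ccncc2)c1` differs from compound 3 in 3-(trifluoromethyl)phenyl in place of (3,4-dichlorophenyl)amino on a carbonyl carbon. Going by the values given here, neither measured step touches the carbonyl carbon; both change only outer substituents, so no measured step bears on this change. With all three numbers in one band, no step beyond the scatter is expected, and the expected step of a number 5 percentage points higher from compound 3 to compound 4 (within the scatter) stays within it. Compound 4 is estimated at 96%, between 78% and 112% in this assay.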

Compound 4, a percentage reported as activity, at one concentration (the size of the read-out at that concentration, not a potency): 103%
Compound 4: the middle estimate sits 7 percentage points below what was measured, within the range that was stated.
By their numbers in this assay, from the lowest: compounds 3, 2, 4 and 1 (each within the scatter of the next, the first and the last beyond it).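

Going by these compounds alone, the carbonyl carbon gives the first single change to read beyond the scatter: a number 12 percentage points higher from compound 3 to compound 4 (beyond the scatter) in this assay, with 3-(trifluoromethyl)phenyl in place of (3,4-dichlorophenyl)amino. This swap changes the amino nitrogen, with its hydrogen-bond donor, and the ring substituents together, so the step cannot be assigned to either one. Nothing available accounts for the step.

Open, on these data alone, is how a 3,4-dichlorophenyl group placed directly on the carbonyl carbon would read, since it would separate the amino nitrogen from the ring substituents.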